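The source may hold more compounds than are shown below. What is called first, only, known or untested is meant among the compounds shown, and "the series" means these compounds.

Measured compounds:
compound 1 `O=S(=O)(NCCNC(=S)Nc1cccc(Cl)c1)c1ccc(-c2ccccc2OCc2ccccc2)s1` – > 50000 nM
compound 2 `O=S(=O)(NCCNC(=S)Nc1ccc(Cl)cc1)c1ccc(-c2ccccc2OCc2ccccc2)s1` – > 50000 nM
compound 3 `COc1ccc(NC(=O)NCCNS(=O)(=O)c2ccc(-c3ccccc3Oc3ccc([N+](=O)[O-])c([N+](=O)[O-])c3)s2)cc1` – 5400 nM

In a functional assay on HL-60 cells (Homo sapiens) for inhibition, read by CCK-8 assay, with a stated time of 48 h (on this read-out lower numbers stand for stronger inhibition and higher numbers for weaker inhibition), compound 1 reaches only the limit of the assay, > 50000 nM. Compound 2 likewise gives only a limit in this assay, > 50000 nM. Within the data shown here, the one step between measured compounds, a step that the two limits leave unreadable from compound 1 to compound 2, therefore has no readable size. Among the measured compounds shown here, compound 3 gives the only real number in this assay, 5400 nM, and so stands alone among the values shown, with the other two resting at the limit of > 50000 nM in this assay, at which 2 of the 3 values shown sit.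

Compound 4 `COc1ccc(NC(=O)NCCNS(=O)(=O)c2ccc(-c3ccccc3OCc3ccccc3)s2)cc1` is not yet measured. It differs from compound 3 by benzyl in place of 3,4-dinitrophenyl on an oxygen on an aromatic ring. For the measured compounds named here, no measured step bears directly on this change, since the only measured step concerns a chlorophenyl group on an amide-type nitrogen. Compound 1 and compound 2, however, both carry benzyl on an oxygen on an aromatic ring and both sit at the limit, while compound 3, with 3,4-dinitrophenyl in that place, gives a number.

Compound 4 is therefore expected to lose activity in this assay, with an expected step of a 5.6-fold higher number from compound 3 to compound 4 (0.74 log units; beyond the scatter). The estimate for compound 4 in this assay is 30000 nM, within a range from 8000 nM to 100000 nM, with a fair chance that only a limit is reported.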

Compound 4, half-maximal inhibitory concentration: > 50000 nM
Compound 4: only a limit was reported (the forecaster's own chance of this, stated with the estimate: 50%); middle value at least 1.6-fold (0.22 log units) from the limit.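

In this assay, benzyl in place of 3,4-dinitrophenyl on an oxygen on an aromatic ring gives an at least 9.2-fold higher number from compound 3 to compound 4 (0.96 log units; beyond the scatter), the only readable step among the compounds shown. Compound 1 and compound 2 also carry benzyl there, but they differ from compound 3 in more than one place, so this pair is the one that ties the loss in this assay to this single change. The steps from compound 1 and from compound 2 to compound 4 cannot be read, with limits at both ends, so with benzyl in place no effect of the group on the amine nitrogen can be sized, and the benzyl compounds all rest at one limit: the limit of > 50000 nM in this assay, at which 3 of the 4 values shown sit.

As far as these compounds go, what a plain phenyl, a phenyl carrying a single nitro group, or a phenyl carrying amino groups in place of the nitro groups would give on that oxygen stays open, so it cannot be told whether the number of compound 3 goes with the nitro groups or with the ring itself. Also open, from the compounds shown here alone, is whether 3,4-dinitrophenyl on that oxygen would bring a readable number to the chlorophenyl series of compound 1 and compound 2.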